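A few compounds are considered here, and "the series" means these few. Any claim that something is new, unique, unknown or untested is made for them only; others in the source may bear on it.

Measured in a functional assay on MDA-MB-231 cells (Homo sapiens) for antiproliferative activity, read by MTT assay; a lower number here means a stronger inhibitor, a higher number a weaker inhibitor:
compound 1 `CC/C=C\C/C=C\C/C=C\CCCCCCCc1cc(=O)c2c(O)cc(OCOC)cc2o1`: 6790 nM
compound 2 `CCCCCCCCCCCCCCCc1cc(=O)c2c(O)c(C)c(OCOC)cc2o1`: > 87000 nM (a limit)
compound 3 `CCCCC/C=C\C/C=C\CCCCCCCc1cc(=O)c2c(O)c(C)c(OCOC)cc2o1`: > 87000 nM (a limit)

Compound 3 gives > 87000 nM, which is a limit and not a number. It therefore has no readable position in the series and sits at the limit of > 87000 nM in this assay, at which 2 of the 3 values shown sit. Compound 2 gives > 87000 nM, which is also a limit. Among the measured compounds shown here, compound 1 gives 6790 nM, the only true number so far.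

The next compound is compound 4 `CC/C=C\C/C=C\C/C=C\CCCCCCCc1cc(=O)c2c(O)c(C)c(OCOC)cc2o1`, and the change is but-1-en-1-yl in place of butyl on a saturated chain carbon bound to a double-bonded chain carbon.

For the measured compounds named here, the one measured step of a similar kind is a step that the two limits leave unreadable from compound 2 to compound 3. It shows that the chain change made there did not bring a number into range, but it gives no size to carry forward. The expectation in this assay is therefore weak: at best a modest move toward stronger inhibition, with a report of only a limit slightly more likely than a number.

The expected step is an at least 1.4-fold lower number from compound 3 to compound 4 (0.16 log units; that floor lies within the scatter). For compound 4 the estimated value is 60000 nM. The expected range for compound 4 runs from 15000 nM to 87000 nM.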

Compound 4, half-maximal inhibitory concentration: 6790 nM
Compound 4: the middle estimate sits 8.8-fold (0.95 log units) above what was measured; the whole stated range lies above it.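

In this assay, but-1-en-1-yl in place of butyl on a saturated chain carbon bound to a double-bonded chain carbon gives an at least 12-fold lower number from compound 3 to compound 4 (1.10 log units; beyond the scatter), a large step, whereas the step from compound 2 to compound 3 cannot be read and gave no size. Measured against the fully saturated chain of compound 2, the change of chain gives an at least 12-fold lower number from compound 2 to compound 4 (1.10 log units; beyond the scatter), so within the methyl-bearing compounds only the chain of compound 4 brings a true number into range. Among the compounds shown here, the pair sharing that chain adds a point the earlier compounds could not show: methyl in place of hydrogen on an aromatic carbon gives no change at the digits printed from compound 1 to compound 4 (within the scatter), so in this assay this methyl leaves the number unchanged when the chain is the one in compound 1 and compound 4.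

As far as these compounds go, compound 2 and compound 3 each give only a limit, and the true size of the large steps measured from them stays open: the limit of > 87000 nM in this assay, at which 2 of the 4 values shown sit. Also open is whether a longer chain, or an amine or a carboxylic acid in place of but-1-en-1-yl, would keep the number of compound 4.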